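The source may hold more compounds than are shown below. What is called first, only, known or untested is meant among the compounds shown, and "the series" means these compounds.

Among the compounds with values here, in an assay on isolated protein for activation of cGMP-dependent protein kinase 1 (Homo sapiens), read by ADP-Glo, with stated times of 30 min and 2 h, in the presence of a further agent that is not named here (a higher number here means that more compound is needed for the effect, a lower number that less compound is needed), compound 3 `Nc1cc(C(=O)O)ccc1CN1CCC[C@H](O[C@H](CO)c2cc(Cl)cc(Cl)c2)[C@@H]1c1ccccc1` gives 290 nM, the lowest of the three numbers measured so far. Compound 2 `O=C(O)c1ccc(CN2CCC[C@H](O[C@H](CO)c3cc(Cl)cc(Cl)c3)[C@@H]2c2ccccc2)c([N+](=O)[O-])c1` gives 520 nM, and the step of a 1.8-fold lower number from compound 2 to compound 3 (0.25 log units; within the scatter) lies within the scatter, so the two cannot be ranked. Compound 1 `Cc1cc(C(=O)O)ccc1C(C)N1CCC[C@H](O[C@H](CO)c2cc(Cl)cc(Cl)c2)[C@@H]1c1ccccc1` gives 18000 nM, and the step of a 62-fold lower number from compound 1 to compound 3 (1.79 log units; beyond the scatter) is well beyond the scatter. The unmeasured compound 4 `COC(=O)Nc1cc(C(=O)O)ccc1CN1CCC[C@H](O[C@H](CO)c2cc(Cl)cc(Cl)c2)[C@@H]1c1ccccc1` differs from compound 3 by methoxycarbonyl in place of hydrogen on a nitrogen on an aromatic ring. Of the measured steps, only the change from nitro to amino touches the same nitrogen on the aromatic ring, and that step was within the scatter; the large step from compound 1 to compound 3 swaps the entire group on the amine nitrogen in the ring and does not speak to a substituent on the aromatic nitrogen. Within the data shown here, no measured pair shows what a methoxycarbonyl on that nitrogen does. The step of a 1.4-fold higher number from compound 3 to compound 4 (0.14 log units; within the scatter) is therefore expected to be small, most likely within the scatter or a slight rise in the number. Compound 4 is estimated at 400 nM, with a range from 150 nM to 1200 nM.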

Compound 4, half-maximal effective concentration: 1000 nM
For compound 4 the middle estimate is 2.5-fold (0.40 log units) below the measured one; the measured number falls inside the stated range.
By their numbers in this assay, from the lowest: compounds 3, 2 and 4 (each within the scatter of the next, the first and the last beyond it); then compound 1.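

In this assay, within the data shown here, methoxycarbonyl in place of hydrogen on a nitrogen on an aromatic ring gives a 3.4-fold higher number from compound 3 to compound 4 (0.54 log units; beyond the scatter), the first step at this position to lie beyond the scatter, which shows that the number responds to what this nitrogen carries, though only modestly. The change from nitro to (methoxycarbonyl)amino gives a 1.9-fold higher number from compound 2 to compound 4 (0.28 log units; within the scatter), so compound 2 can be separated from neither compound 3 nor compound 4, even though those two differ from each other. No measurement given here bears on why the methoxycarbonyl raises the number.

On these data alone, it remains open whether the rise belongs to the methoxycarbonyl as a whole or to any carbonyl on this nitrogen, which an acetyl group could test. A methyl group or a longer ethoxycarbonyl group on the same nitrogen is also left open.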